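Trading the amine's alkyl tail for a carboxymethyl group

This account rests on a few compounds, and the source may have more. Where it says the series, first, only, none or still open, it means among the compounds named here.

Measured compounds in an assay on AV12 cells for binding affinity to Neuropeptide Y receptor type 1 (Homo sapiens); a lower number here means a stronger inhibitor, a higher number a weaker inhibitor:
compound 1 `CCCN1CCC(CCCn2c(COc3ccc(Cl)cc3)nc3c(C)cccc32)CC1`: 29 nM
compound 2 `Cc1cccc2c1nc(COc1ccc(Cl)cc1)n2CCCC1CCN(CCC(C)C)CC1`: 11 nM

For the measured compounds named here, compound 2 gives the lower of the two numbers; the only measured step, a 2.6-fold lower number from compound 1 to compound 2 (0.42 log units; beyond the scatter), is modest. Compound 3 `Cc1cccc2c1nc(COc1ccc(Cl)cc1)n2CCCC1CCN(CC(=O)O)CC1` is compound 2 with carboxy in place of isobutyl on a saturated chain carbon bound to an amine nitrogen in a ring. That step bears on compound 3 only loosely: it changed the far end of the same chain on the ring amine, and stayed small. Going by the values given here, no measured step exchanges an alkyl group for a carboxy group, so the expectation rests on the structural change alone. Compound 3 is expected to bind more weakly, an estimated step of a 27-fold higher number from compound 2 to compound 3 (1.44 log units; beyond the scatter). The estimate for compound 3 is 300 nM, with a range from 50 nM to 3000 nM.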

Compound 3, inhibition constant: 2190 nM
Beside the measured number, compound 3's estimate is 7.3-fold (0.86 log units) below it, and the stated range covers the measured number.
By their numbers in this assay, from the lowest: compound 2; then compound 1; then compound 3.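

In this assay, carboxy in place of isobutyl gives a 200-fold higher number from compound 2 to compound 3 (2.30 log units; beyond the scatter), and carboxy in place of ethyl gives a 76-fold higher number from compound 1 to compound 3 (1.88 log units; beyond the scatter). For the compounds shown here, both steps are large, so the tail on the ring amine, which had so far shifted the number only modestly, can also change it greatly. Nothing available explains this loss.

Still open, going by these compounds, is whether the loss follows the carboxylic acid itself or the oxygen-bearing tail more generally. A methyl ester or primary amide in place of carboxy, or a longer chain ending in a carboxylic acid, would bear on that.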